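A few compounds are considered here, and "the series" means these few. Any claim that something is new, unique, unknown or untested is made for them only; others in the source may bear on it.

Working notes on the series. The shared core is that of compound 1 `Cc1nc(N2CCN(S(C)(=O)=O)CC2)nc2ccc(NC(=O)COc3ccc(Cl)cc3)cc12`. In an assay on CHO-K1 cells for displacement of a labelled ligand from melanin-concentrating hormone receptor 1 (Homo sapiens), with a stated time of 2 h (a lower number here means a stronger inhibitor, a higher number a weaker inhibitor), compound 1 gives no number, only a limit of the assay, > 10000 nM. Compound 2 `Cc1nc(N2CCN(C(=O)C3CC3)CC2)nc2ccc(NC(=O)COc3ccc(OC(F)(F)F)cc3)cc12` differs from compound 1 in two places at once, and in this assay compound 2 gives 49 nM. For the measured compounds named here, no single step between measured compounds exists, so the pair shows only that one member reads at the limit (the limit of > 10000 nM in this assay, at which 1 of the 2 values shown sits) while the other reads well inside the measurable range; which of the two changes carries the difference cannot be told from these two values alone.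

Compound 3 `Cc1nc(N2CCN(CC(C)(C)C)CC2)nc2ccc(NC(=O)COc3ccc(Cl)cc3)cc12` is the next compound to be tested. Relative to compound 1 the change is neopentyl in place of methylsulfonyl on an amine nitrogen in a ring. Going by the values given here, no measured step matches it. A step of clear size toward stronger binding is nevertheless expected, an at least 33-fold lower number from compound 1 to compound 3 (1.52 log units; beyond the scatter). Compound 3 is estimated to give about 300 nM in this assay, with a range of 30 nM to 5000 nM.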

Compound 3, half-maximal inhibitory concentration: 782 nM
Beside the measured number, compound 3's estimate is 2.6-fold (0.42 log units) below it; low and high end bracket the measured number.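

The series now holds a comparison in one place, on the amine nitrogen of the six-membered ring: in this assay, neopentyl in place of methylsulfonyl gives an at least 12-fold lower number from compound 1 to compound 3 (1.10 log units; beyond the scatter). A change at this position alone, with the rest of the core of compound 1 kept, is thus enough to bring a compound into the measurable range. Compound 1 gives > 10000 nM, which is a limit of the assay and not a number, so the true size of the step stays unknown: the limit of > 10000 nM in this assay, at which 1 of the 3 values shown sits.

Open, from the compounds shown here alone, is how this nitrogen reads with a free amine hydrogen, a methyl group or a longer straight chain such as n-pentyl in place of neopentyl. Also open, going by these compounds, is whether neopentyl reads the same with the trifluoromethoxy group of compound 2 in place of the chlorine.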